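Swapping the Amine Chain for a Chloropyridyl Ring

The compounds below may be only part of what the source reports. "The series", "measured", "known", "first", "only" and "open" are said of these compounds alone.

Compound 2 `CN(C)CCC(=O)Nc1cccc(-c2nc3ccccc3s2)c1` stands at the top of the three measured compounds in a physicochemical assay for solubility, in phosphate buffer, measured as kinetic solubility, with a stated time of 18 h, at pH 7.4 (a lower number here means a less soluble compound, a higher number a more soluble compound), where compound 2 gives 56000 nM. Compound 1 `C/C=C/C(=O)Nc1cccc(-c2nc3ccccc3s2)c1` gives 110 nM, and compound 3 `O=C(CCl)Nc1cccc(-c2nc3ccccc3s2)c1` gives 1000 nM. The step of a 510-fold higher number from compound 1 to compound 2 (2.71 log units; beyond the scatter) and the step of a 56-fold lower number from compound 2 to compound 3 (1.75 log units; beyond the scatter) both show that the 2-(dimethylamino)ethyl group of compound 2 goes with the highest number, while the step of a 9.1-fold higher number from compound 1 to compound 3 (0.96 log units; beyond the scatter) separates the two compounds that lack it. Compound 4 `O=C(Nc1cccc(-c2nc3ccccc3s2)c1)c1ccnc(Cl)c1` carries 2-chloropyridin-4-yl in place of 2-(dimethylamino)ethyl on a carbonyl carbon, so the group that went with the highest number is gone and an aromatic ring enters in its place. Because the steps of a 510-fold higher number from compound 1 to compound 2 (2.71 log units; beyond the scatter) and a 56-fold lower number from compound 2 to compound 3 (1.75 log units; beyond the scatter) were large, a large fall in this assay is expected from compound 2 to compound 4, estimated as a 220-fold lower number from compound 2 to compound 4 (2.35 log units; beyond the scatter). Compound 4 is therefore expected to give 250 nM, with a range from 50 nM to 1500 nM. That would place it among the numbers of compound 1 and compound 3 rather than that of compound 2.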

Compound 4, solubility: 740 nM
Compound 4: middle estimate off by 3.0-fold (0.47 log units), on the low side; the measured number falls inside the stated range.
By their numbers in this assay, from the lowest: compound 1; then compounds 4 and 3 (each within the scatter of the next); then compound 2.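

In this assay, compound 4 brings an aromatic ring to the carbonyl carbon, the first among the compounds shown, and the result is a 76-fold lower number from compound 2 to compound 4 (1.88 log units; beyond the scatter), so this ring does not hold the number seen with 2-(dimethylamino)ethyl. With a 1.4-fold lower number from compound 3 to compound 4 (0.13 log units; within the scatter), the 2-chloropyridin-4-yl and chloromethyl groups cannot be told apart at this position. Against prop-1-en-1-yl there is still a gain, a 6.7-fold higher number from compound 1 to compound 4 (0.83 log units; beyond the scatter), leaving compound 2 alone at the top and compound 1 lowest of the four, though nothing given here explains these differences.

Going by these compounds, whether a dimethylamino group carried on the aromatic ring, or a morpholine at the same carbonyl carbon, would come closer to compound 2 remains open. Also open, on these data alone, is how a pyridin-4-yl group without the chlorine would compare with compound 4.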